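Trifluoromethyl in Place of Hydroxy on the Aryl Ring

The compounds below may be only part of what the source reports. "The series", "measured", "known", "first", "only" and "open" are said of these compounds alone.

Of the compounds shown here, three sharing one core have so far been measured in a functional assay (aorta) for inhibition, with Rattus norvegicus as the target; a lower number here means a stronger inhibitor, a higher number a weaker inhibitor. Compound 1 `C#Cc1ccc2c(c1)[C@@H](/N=C(\NC#N)Nc1ccccc1)[C@H](O)C(C)(C)O2` gives 5400 nM. Compound 2 `CC1(C)Oc2ccc(C#N)cc2[C@@H](/N=C(\S)Nc2ccccc2)[C@@H]1O` gives 1700 nM. Compound 3 `CC1(C)Oc2ccc(C#N)cc2[C@@H](/N=C(\NC#N)Nc2ccc(O)cc2)[C@@H]1O` gives 2200 nM. Of these three numbers, compound 3 holds the second highest; its number and that of compound 2 lie within the scatter of each other, whereas compound 1 shows a number higher than that of compound 3 by more than the scatter.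

Compound 4 `CC1(C)Oc2ccc(C#N)cc2[C@@H](/N=C(\NC#N)Nc2ccc(C(F)(F)F)cc2)[C@@H]1O` has not yet been measured in this assay. It differs from compound 3 in a single place: trifluoromethyl in place of hydroxy on an aromatic carbon. Going by the values given here, no pair of measured compounds in this set differs by exactly this change, so there is no directly comparable step to lean on, and the measured numbers give no guide to the direction of the change on their own. The step expected from compound 3 to compound 4 in this assay is therefore small, at most a modest move toward a lower number, and quite possibly none beyond the scatter: a 1.5-fold lower number from compound 3 to compound 4 (0.17 log units; within the scatter). On that basis compound 4 is expected to give about 1500 nM in this assay, with a plausible range from 500 nM to 5000 nM.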

Compound 4, half-maximal inhibitory concentration: 8100 nM
For compound 4 the middle estimate is 5.4-fold (0.73 log units) below the measured one; measured number outside the range, above it.
By their numbers in this assay, from the lowest: compounds 2 and 3 (each within the scatter of the next); then compounds 1 and 4 (each within the scatter of the next).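

Trifluoromethyl in place of hydroxy on an aromatic carbon, para to a large group, gives in this assay a 3.7-fold higher number from compound 3 to compound 4 (0.57 log units; beyond the scatter), so this place on the aryl ring is not indifferent to the group it carries. Going by these compounds alone, the earlier compounds offered no pair differing in one place, which makes this the first single change in the set that can be read, and it shows that, of these two groups, the compound with hydroxy is the stronger inhibitor. No measurement shown here ties this step to any property of either group.

Within the data shown here, one pair cannot separate what the departing hydroxy contributes from what the entering trifluoromethyl contributes, and compound 1, the one compound with an unsubstituted phenyl, differs from both elsewhere, so it cannot serve as a midpoint. On these data alone, how an amine, a methoxy group or a carboxylic acid would behave at this same place remains open, as does whether the same change would give a step of similar size on a compound that differs elsewhere.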